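Amide Substitution on the Piperidine Nitrogen and Hepatocyte Clearance

This account rests on a few compounds, and the source may have more. Where it says the series, first, only, none or still open, it means among the compounds named here.

Measured compounds:
compound 1, `CC(C)n1cc(-c2ccnc3[nH]c(C4CCNCC4)cc23)ccc1=O`, < 1 uL/min
compound 2, `CC(C)n1cc(-c2ccnc3[nH]c(C4CCN(CC(=O)N(C)C)CC4)cc23)cnc1=O`, 100 uL/min

Both measured compounds share a core and a six-membered non-aromatic ring with one nitrogen. In an ADME assay on cells (Hepatocyte, Rattus norvegicus) for metabolic stability (on this read-out higher numbers stand for fast clearance and lower numbers for slow clearance), compound 1 gives < 1 uL/min, which is a limit of the assay and not a number (the limit of < 1 uL/min in this assay, at which 1 of the 2 values shown sits). In this assay compound 2 gives 100 uL/min. Compound 2 differs from compound 1 in more than one place, so the two values show only that they lie far apart, well beyond the usual scatter.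

Compound 3, `CC(C)n1cc(-c2ccnc3[nH]c(C4CCN(CC(=O)N5CCCCC5)CC4)cc23)ccc1=O`, has not yet been measured. It differs from compound 1 by ((piperidin-1-yl)carbonyl)methyl in place of hydrogen on an amine nitrogen in a ring. Compound 3 carries a substituent on the amine nitrogen in a ring, as compound 2 does, and compound 2 gives 100 uL/min in this assay. The step from compound 1 to compound 3 is therefore expected to be an increase in clearance well beyond the scatter, an at least 30-fold higher number from compound 1 to compound 3 (1.47 log units; beyond the scatter). Compound 3 is expected to give 30 uL/min, within a range from 5 uL/min to 150 uL/min.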

Compound 3, intrinsic clearance in a liver preparation (reported as CLH), per the amount of preparation that the assay uses: 26 uL/min
The estimate for compound 3 lay 1.2-fold (0.06 log units) above the measured number; low and high end bracket the measured number.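

With the rest of the molecule unchanged, placing ((piperidin-1-yl)carbonyl)methyl on the amine nitrogen in a ring gives in this assay an at least 26-fold higher number from compound 1 to compound 3 (1.41 log units; beyond the scatter), so a large rise in clearance can now be tied to this one place, which the earlier pair, differing in more than one place, could not show. Compound 1 gives < 1 uL/min, which is a limit of the assay and not a number. The size of the step is therefore known only from one side: the limit of < 1 uL/min in this assay, at which 1 of the 3 values shown sits.

The compounds shown leave open which part of the new substituent goes with the rise, as a simple methyl or a longer alkyl chain on the same nitrogen would help to tell. On these data alone, it also remains open how a carboxylic acid at the end of the substituent, in place of the piperidine amide, would read in this assay.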